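The compounds below may be only part of what the source reports. "The series", "measured", "known", "first", "only" and "open" are said of these compounds alone.

Three compounds sharing one core, and differing only in the aromatic ring attached to the nitrogen of that core, have been tested in a functional assay on MGC-803 cells (Homo sapiens) for inhibition, read by MTT assay, with a stated time of 72 h; on this read-out higher numbers stand for weaker inhibition and lower numbers for stronger inhibition. Compound 1 `C#CCSc1nc(Nc2ccc(F)cc2)c2ccncc2n1` gives 15800 nM. Compound 2 `C#CCSc1nc(Nc2ccc(Cl)cc2)c2ccncc2n1` gives 16400 nM; the step of a 1.0-fold higher number from compound 1 to compound 2 (0.02 log units; within the scatter) shows that swapping one halogen for the other at the same spot changed nothing of note. Compound 3 `C#CCSc1nc(Nc2cccc(Cl)c2)c2ccncc2n1` gives 2190 nM, the lowest and therefore the strongest inhibition of the three: the steps of a 7.2-fold lower number from compound 1 to compound 3 (0.86 log units; beyond the scatter) and a 7.5-fold lower number from compound 2 to compound 3 (0.87 log units; beyond the scatter) show that where the substituent sits on the ring matters more than which halogen it is.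

Compound 4 `C#CCSc1nc(Nc2ccccc2O)c2ccncc2n1` has not yet been measured. Its change from compound 3 is 2-hydroxyphenyl in place of 3-chlorophenyl on a nitrogen on an aromatic ring. Going by the values given here, no measured step involves a hydroxyl group, so the closest guides are indirect: the halogen swap was within the scatter, while moving the substituent to a different position on the ring gave the modest steps above. Because compound 3 holds the lowest value 2190 nM and both the group and its position now change at once, a return toward higher numbers is expected, and the step of a 3.7-fold higher number from compound 3 to compound 4 (0.56 log units; beyond the scatter) is estimated with wide uncertainty. Compound 4 is expected to give about 8000 nM, within 2000 nM to 30000 nM.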

Compound 4, half-maximal inhibitory concentration: 21000 nM
Beside the measured number, compound 4's estimate is 2.6-fold (0.42 log units) below it; low and high end bracket the measured number.
By their numbers in this assay, from the lowest: compound 3; then compounds 1, 2 and 4 (each within the scatter of the next).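

In this assay, replacing 3-chlorophenyl with 2-hydroxyphenyl on this nitrogen loses the advantage seen in compound 3 (a 9.6-fold higher number from compound 3 to compound 4 (0.98 log units; beyond the scatter)), so the better result of compound 3 does not carry over to just any substituted phenyl ring here. Compound 4 instead sits level with the two halogen compounds that carry 4-fluorophenyl (a 1.3-fold higher number from compound 1 to compound 4 (0.12 log units; within the scatter)) and 4-chlorophenyl (a 1.3-fold higher number from compound 2 to compound 4 (0.11 log units; within the scatter)), which leaves compound 3 as the strongest of the four and shows that a ring with a hydrogen-bond donor and acceptor and no halogen reads the same as those rings in this assay. No measurement shown here explains the difference between these groups.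

The group and its place on the ring change together in this step, so the loss cannot be divided between them; a chlorine in the place the hydroxyl holds in compound 4, or a hydroxyl in the place the chlorine holds in compound 3, would each change only one of the two. Also open, on these data alone, is how an amine or a methoxy group would compare with chlorine in the place it holds in compound 3.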